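Thiourea amide series: aryl swap on the thiourea nitrogen

The source may report more compounds than this note shows. Statements on the series, on what has been measured and on what is new or still open speak of the compounds shown alone.

Measured so far, in a functional assay on HCT-116 cells (Homo sapiens) for cytotoxicity, read by MTT assay, with a stated time of 48 h; a lower number here means a stronger inhibitor, a higher number a weaker inhibitor:
- compound 1 `CNC(=O)c1cc(Oc2cccc(NC(=S)Nc3cccc(C(F)(F)F)c3)c2)ccn1` gives 25300 nM
- compound 2 `O=C(NC1CCCCC1)c1cc(Oc2cccc(NC(=S)Nc3cccc(C(F)(F)F)c3)c2)ccn1` gives 8400 nM
- compound 3 `O=C(NCc1ccccc1)c1cc(Oc2cccc(NC(=S)Nc3cccc(C(F)(F)F)c3)c2)ccn1` gives 7500 nM

Compound 3 has the lowest number of the three. Its gap to compound 2 is within the scatter, so the two cannot be ordered; its gap to compound 1 is beyond it, seen as a 3.4-fold lower number from compound 1 to compound 3 (0.53 log units; beyond the scatter), and the companion step a 3.0-fold lower number from compound 1 to compound 2 (0.48 log units; beyond the scatter) shows the same size of gain when the methyl on the amide nitrogen is replaced by a larger group. The step of a 1.1-fold lower number from compound 2 to compound 3 (0.05 log units; within the scatter) is flat.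

Compound 4 `O=C(NCc1ccccc1)c1cc(Oc2cccc(NC(=S)Nc3ccc(OC(F)(F)F)cc3)c2)ccn1` is the next compound. It differs from compound 3 by 4-(trifluoromethoxy)phenyl in place of 3-(trifluoromethyl)phenyl on an amide-type nitrogen. All three measured steps concern the amide nitrogen only; none touches the thiourea aryl, so none bears directly on this change. With no comparison to lean on, the expectation is that compound 4 stays near compound 3 in this assay, with no step beyond the scatter: a 1.1-fold higher number from compound 3 to compound 4 (0.03 log units; within the scatter) is the expected outcome. Compound 4 is therefore estimated at 8000 nM, within a range of 3000 nM to 20000 nM.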

Compound 4, half-maximal inhibitory concentration: 7400 nM
Estimate against measurement, compound 4: 1.1-fold (0.03 log units) above; the measured number falls inside the stated range.
By their numbers in this assay, from the lowest: compounds 4, 3 and 2 (each within the scatter of the next); then compound 1.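

Within the data shown here, this is the first look at the aryl group on the amide-type nitrogen whose other neighbour is the thiocarbonyl carbon, and in this assay the exchange of 3-(trifluoromethyl)phenyl for 4-(trifluoromethoxy)phenyl gives a 1.0-fold lower number from compound 3 to compound 4 (0.01 log units; within the scatter) on the benzyl amide. Among these compounds, the earlier compounds varied only the amide nitrogen, so this is the first sign that the thiourea aryl can carry a different substituent at a different ring position, including the added oxygen and hydrogen-bond acceptor of the entering group, without a step beyond the scatter. The two substituent changes are made together here, so the flat result cannot be split between them, and no measurement available explains it.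

As far as these compounds go, whether the same exchange stays flat on the methyl or cyclohexyl amide remains open. Also open, from the compounds shown here alone, is how the series responds to an unsubstituted phenyl, a pyridine or a 4-(dimethylamino)phenyl on the thiourea nitrogen, or to a urea carbonyl in place of the thiocarbonyl.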